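Carbonyl-side exchange in the aminoquinoline series: cytotoxicity notes

This account rests on a few compounds, and the source may have more. Where it says the series, first, only, none or still open, it means among the compounds named here.

Among the measured compounds shown here, compound 3 `COc1cc(NC(C)CCCNC(=O)NNC(=O)/C=C/c2ccccc2)c2ncccc2c1` gives 13900 nM in an ADME assay on L6 cells (Rattus norvegicus) for cytotoxicity, read by resazurin assay, with a stated time of 70 h (a lower number here means a stronger inhibitor, a higher number a weaker inhibitor), the lowest of the two numbers so far, though compound 2 `COc1cc(NC(C)CCCNC(=O)/C=C/c2ccc(Cl)cc2)c2ncccc2c1` with 16800 nM sits within the scatter of it. For compound 1 `COc1cc(NC(C)CCCNC(=O)/C(C)=C/c2ccccc2)c2ncccc2c1` the assay reports only a limit, > 250000 nM, as recorded in the limit of > 250000 nM in this assay, at which 1 of the 3 values shown sits.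

Compound 4 `COc1cc(NC(C)CCCNC(=O)NNC(=O)Nc2cccc(Cl)c2)c2ncccc2c1` differs from compound 3 by (3-chlorophenyl)amino in place of 2-phenylethenyl on a carbonyl carbon. For the measured compounds named here, the single measured step at a carbonyl carbon, an at least 14-fold lower number from compound 1 to compound 2 (1.17 log units; beyond the scatter), shows that exchanges at this position can shift the number widely, but it starts from a limit and concerns other groups, so it guides only loosely. Going by the values given here, no measured step covers the present exchange. For compound 4 a step of a 1.4-fold higher number from compound 3 to compound 4 (0.16 log units; within the scatter) is expected, within the scatter. Compound 4 is therefore estimated at 20000 nM, with a range from 5000 nM to 120000 nM.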

Compound 4, half-maximal inhibitory concentration: 58600 nM
The estimate for compound 4 lay 2.9-fold (0.47 log units) below the measured number; the range from low to high includes it.
By their numbers in this assay, from the lowest: compounds 3 and 2 (each within the scatter of the next); then compound 4. At a limit, above all of these: compound 1.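

On the carbonyl carbon whose other neighbour is an amide-type nitrogen, (3-chlorophenyl)amino in place of 2-phenylethenyl moves the number in this assay: a 4.2-fold higher number from compound 3 to compound 4 (0.62 log units; beyond the scatter). Both groups hold the same count of heavy atoms and one aromatic ring each, and unlike the step from compound 1 to compound 2, this step is read between two numbers, not from a limit. Nothing measured here gives a cause for this step.

The chlorine and the amino nitrogen enter together, and the compounds shown do not separate them. Also open, as far as these compounds go, is how a plain phenylamino or a benzyl group on this carbonyl carbon would read.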